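The compounds below may be only part of what the source reports. "The series", "measured", "known", "first", "only" and "open" are said of these compounds alone.

Measured compounds:
Compound 1 `Brc1nn(-c2ccc3ncccc3c2)c2nc(N[C@@H]3CC[C@@H](c4ncc[nH]4)C3)ncc12`, 545 nM
Compound 2 `CNS(=O)(=O)[C@@H]1CC[C@@H](Nc2ncc3c(Br)nn(-c4ccc5ncccc5c4)c3n2)C1`, 106 nM
Compound 3 `CS(=O)(=O)N1CC[C@@H](Nc2ncc3c(Br)nn(-c4ccc5ncccc5c4)c3n2)C1`, 378 nM

In an assay on SK-OV-3 cells for inhibition of eIF-2-alpha kinase GCN2 (Homo sapiens) (a higher number here means a weaker inhibitor, a lower number a stronger inhibitor), compound 3 stands second highest of the three numbers. Its nearest neighbour is compound 1, whose number sits a 1.4-fold lower number from compound 1 to compound 3 (0.16 log units; within the scatter) away from it, within the scatter; the furthest is compound 2, reached by a 3.6-fold higher number from compound 2 to compound 3 (0.55 log units; beyond the scatter) in the other direction, which is beyond the scatter.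

Compound 4 `CNC(=O)[C@]1(C)CC[C@@H](Nc2ncc3c(Br)nn(-c4ccc5ncccc5c4)c3n2)C1` is not yet measured. Relative to compound 3 it carries a group of 10 heavy atoms (8 carbon, 1 nitrogen, 1 oxygen; one five-membered non-aromatic ring of carbon only) in place of a group of 9 heavy atoms (5 carbon, 1 nitrogen, 2 oxygen, 1 sulfur; one five-membered non-aromatic ring with 1 hetero atom), on a nitrogen on an aromatic ring.

Among the measured compounds shown here, two measured steps bear on this. The step of a 3.6-fold higher number from compound 2 to compound 3 (0.55 log units; beyond the scatter) shows that moving from a carbon-only five-membered ring bearing a sulfonamide to a nitrogen-containing ring with the sulfonyl on the ring nitrogen cost potency; compound 4 returns to a carbon-only ring. For the measured compounds named here, the step of a 5.1-fold lower number from compound 1 to compound 2 (0.71 log units; beyond the scatter) shows that the substituent on that carbon ring matters, and compound 4 carries an amide rather than a sulfonamide, for which no measured step exists. As far as these compounds go, the expected step for compound 4 is therefore a modest fall in this assay, a 2.4-fold lower number from compound 3 to compound 4 (0.37 log units; beyond the scatter), with real uncertainty because the amide is untested. Compound 4 is estimated at 160 nM, within a range of 50 nM to 500 nM.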

Compound 4, half-maximal inhibitory concentration: 21 nM
For compound 4 the middle estimate is 7.6-fold (0.88 log units) above the measured one, outside the stated range (below it).
By their numbers in this assay, from the lowest: compound 4; then compound 2; then compounds 3 and 1 (each within the scatter of the next).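

At the nitrogen on an aromatic ring, the entering group gives an 18-fold lower number from compound 3 to compound 4 (1.26 log units; beyond the scatter) in this assay and so moves the series well past what the earlier changes reached. Compounds 1 and 2 had already shown that the substituent on the carbon-only ring matters, but compound 4 shows that this ring can carry a group other than the sulfonamide and still improve, with a 5.0-fold lower number from compound 2 to compound 4 (0.70 log units; beyond the scatter) and a 26-fold lower number from compound 1 to compound 4 (1.41 log units; beyond the scatter) leaving compound 4 with the lowest number of the four. The data at hand give no measurement that accounts for this gain.

Compound 4 differs from compound 2 both in the amide that replaces the sulfonamide and in the added methyl on the same ring carbon, and the compounds shown leave open which of the two carries the step, as the amide without that methyl is not among them. Also open, as far as these compounds go, is how far the gain extends to related groups, such as a primary amide, a carboxylic acid, or an ethyl in place of the methyl on the amide nitrogen.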